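A few compounds are considered here, and "the series" means these few. Any claim that something is new, unique, unknown or untested is made for them only; others in the source may bear on it.

Of the compounds shown here, three have been tested in an ADME assay on microsomes from liver (Homo sapiens) for metabolic stability, read by LC-MS, with a stated time of 30 min, tested at 1 uM (a lower number here means that less of the compound is left, a higher number that more of the compound is left), so far: compound 1 `O=C(NCc1ccc(S(=O)(=O)N2CCCCC2)cc1)c1cc2cnccc2s1` gives 15%, compound 2 `O=C(NCc1ccc(S(=O)(=O)N2CCCCC2)cc1)c1ccn2cncc2c1` gives 54%, and compound 3 `Cc1cccc(S(=O)(=O)c2ccc(CNC(=O)c3cc4cnccc4[nH]3)cc2)c1` gives 49%. Compound 3 therefore stands second highest of the three; its nearest neighbour is compound 2, within the scatter, and its furthest is compound 1, well beyond it.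

Compound 4 `O=C(NCc1ccc(S(=O)(=O)c2ccccc2C(F)(F)F)cc1)c1cc2cnccc2[nH]1` is the next step from compound 3: 2-(trifluoromethyl)phenyl in place of 3-methylphenyl on a sulfonyl sulfur.

Among the compounds with values here, the only step measured so far, a number 39 percentage points higher from compound 1 to compound 2 (beyond the scatter), changes the core attached to the carbonyl and leaves the sulfonyl end untouched, so it says nothing about the present change. Within the data shown here, no measured step bears on it, and no step beyond the scatter is expected in this assay.

Compound 4 is therefore estimated at 52%, between 30% and 72%, which would mean an expected step of a number 3 percentage points higher from compound 3 to compound 4 (within the scatter).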

Compound 4, percent of the compound remaining: 52%
Beside the measured number, compound 4's estimate shows no gap at the digits printed; low and high end bracket the measured number.
By their numbers in this assay, from the lowest: compound 1; then compounds 3, 4 and 2 (each within the scatter of the next).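

Placing 2-(trifluoromethyl)phenyl in place of 3-methylphenyl on a sulfonyl sulfur gives a number 3 percentage points higher from compound 3 to compound 4 (within the scatter) in this assay. Within the data shown here, this is the first measured step at this position, and it shows that a group with more heavy atoms can enter here without a change beyond the scatter. Among these compounds, nothing measured so far bears on why the number holds.

The entering group differs from the leaving one in both its substituent and where that substituent sits, so these two changes cannot be separated. As far as these compounds go, how a plain phenyl, or a phenyl carrying an amine or a carboxylic acid, would behave on this sulfur remains open.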